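Changing the aromatic group on the shared core

The compounds below may be only part of what the source reports. "The series", "measured", "known", "first", "only" and "open" are said of these compounds alone.

Compound 1 `Cn1c(=O)cnn(CCCCN2CCN(c3ccccc3OCCCF)CC2)c1=O` gives 280 nM in an assay for displacement of a labelled ligand from Adrenergic receptor alpha-1 (Homo sapiens); on this read-out higher numbers stand for weaker inhibition and lower numbers for stronger inhibition.
Compound 2 `CNc1ccccc1N1CCN(CCCCn2ncc(=O)n(C)c2=O)CC1` gives 450 nM in this assay.
Compound 3 `CSc1ccccc1N1CCN(CCCCn2ncc(=O)n(C)c2=O)CC1` gives 1.8 nM in this assay.

Compound 3 stands lowest of the three, with a 160-fold lower number from compound 1 to compound 3 (2.19 log units; beyond the scatter) and a 250-fold lower number from compound 2 to compound 3 (2.40 log units; beyond the scatter) separating it from the others. Compound 4 `Cn1c(=O)cnn(CCCCN2CCN(c3c(Br)cccc3C#N)CC2)c1=O` carries 2-bromo-6-cyanophenyl in place of 2-(methylsulfanyl)phenyl on an amine nitrogen in a ring. Neither measured step involves a bromine or a nitrile, so no direct guide exists; the two steps do show that the group on this ring shifts the number strongly. The change is therefore expected to matter, most likely as a higher number, a 17-fold higher number from compound 3 to compound 4 (1.22 log units; beyond the scatter). Compound 4 is estimated at 30 nM, within a range of 4 nM to 300 nM.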

Compound 4, inhibition constant: 450 nM
Compound 4: the middle estimate sits 15-fold (1.18 log units) below what was measured, and the stated range ends below it.
By their numbers in this assay, from the lowest: compound 3; then compounds 1, 2 and 4 (each within the scatter of the next).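

In this assay, the new group shows that a large gain at this position is not shared by every substituted phenyl: there is a 250-fold higher number from compound 3 to compound 4 (2.40 log units; beyond the scatter), yet no change at the digits printed from compound 2 to compound 4 (within the scatter). Among these four compounds, only compound 3, with 2-(methylsulfanyl)phenyl, stands apart, while three quite different groups give numbers within the scatter of the next. No measurement shown here accounts for this gap.

Still open, going by these compounds, is whether a phenyl carrying only the bromine or only the nitrile would read like compound 4. On these data alone, it is also open whether ethylsulfanyl or methoxy would keep the low number of compound 3.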